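Ascorbate-Derived Triazoles: Swapping a Sulfonamide for Pentylphenyl

The compounds below may be only part of what the source reports. "The series", "measured", "known", "first", "only" and "open" are said of these compounds alone.

The measured compounds and their numbers in a functional assay on HCT-116 cells (Homo sapiens) for antiproliferative activity, read by MTT assay, with a stated time of 72 h (a lower number here means a stronger inhibitor, a higher number a weaker inhibitor), are:
compound 1, `O=C1O[C@H]([C@@H](O)Cn2cc(CNS(=O)(=O)c3ccc(Cl)cc3F)nn2)C(OCc2ccccc2)=C1OCc1ccccc1`, 21600 nM;
compound 2, `O=C1O[C@H]([C@@H](O)Cn2cc(CNS(=O)(=O)c3ccc(F)cc3)nn2)C(OCc2ccccc2)=C1OCc1ccccc1`, 22900 nM;
compound 3, `O=C1O/C(=C\Cn2cc(-c3cccc(O)c3)nn2)C(OCc2ccccc2)=C1OCc1ccccc1`, 63600 nM.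

Compound 2 stands second highest of the three numbers, close to compound 1 and furthest from compound 3, whose number is higher. Going by the values given here, the only step between measured compounds that differ in one place is a 1.1-fold higher number from compound 1 to compound 2 (0.03 log units; within the scatter), which concerns the aryl group on the sulfonyl sulfur and lies within the scatter.

Compound 4, `CCCCCc1ccc(-c2cn(C[C@H](O)[C@H]3OC(=O)C(OCc4ccccc4)=C3OCc3ccccc3)nn2)cc1`, differs from compound 2 by the change (4-pentylphenyl in place of (((4-fluorophenyl)sulfonyl)amino)methyl on an aromatic carbon). Among the compounds with values here, no measured step touches this position in this way, so the change cannot be read from the steps at hand; the step from compound 1 to compound 2 bears on a different part of the molecule and says nothing about replacing the whole sulfonamide-bearing group. Compound 3 carries an aryl directly on the same kind of ring but on a different core, and its number is higher than that of compound 2.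

Compound 4 is therefore expected to give 15000 nM in this assay, within 5000 nM to 45000 nM, corresponding to an estimated step of a 1.5-fold lower number from compound 2 to compound 4 (0.18 log units; within the scatter) that may well remain within the scatter.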

Compound 4, half-maximal inhibitory concentration: 13800 nM
Beside the measured number, compound 4's estimate is 1.1-fold (0.04 log units) above it; measured number inside the range.
By their numbers in this assay, from the lowest: compounds 4, 1 and 2 (each within the scatter of the next); then compound 3.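

In this assay, exchanging the whole (((4-fluorophenyl)sulfonyl)amino)methyl group for 4-pentylphenyl on this aromatic carbon gives a 1.7-fold lower number from compound 2 to compound 4 (0.22 log units; within the scatter). The step between compound 1 and compound 2 altered only the aryl group on the sulfonyl sulfur, whereas this change removes the sulfonyl and amino parts altogether and still stays within the scatter. The group that leaves has 1 hydrogen-bond donor and 2 hydrogen-bond acceptors and the group that enters has 0 of each, yet nothing available explains why the number holds.

The compounds shown leave open what the pentyl chain contributes, which a plain phenyl, 4-methylphenyl or 4-aminophenyl group on the same carbon would help to separate from that of the ring. Also open, as far as these compounds go, is how a carboxylic acid at the end of the chain would read in this assay.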